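This account rests on a few compounds, and the source may have more. Where it says the series, first, only, none or still open, it means among the compounds named here.

In a functional assay on LOX IMV1 cells (Homo sapiens) for antiproliferative activity (a higher number here means a weaker inhibitor of growth, a lower number a stronger inhibitor of growth), two compounds of this series have been measured so far. Compound 1, `CC(=O)Nc1ccc(S(=O)(=O)NNC(=O)c2cccnc2Nc2ccc(Cl)cc2)cc1`, gives 24000 nM, and compound 2, `O=C(NNS(=O)(=O)c1ccc(F)cc1)c1cccnc1Nc1ccc(Cl)cc1Cl`, gives 32400 nM. Within the data shown here, these two values lie within the scatter of each other, so compound 1 stands level with the only other compound measured, even though the two structures differ in more than one place. Among the measured compounds shown here, no measured pair differs in one place only, so the data offer no direct reading of any single change.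

Compound 3, `O=C(NNS(=O)(=O)c1ccc(Cl)cc1Cl)c1cccnc1Nc1ccc(Cl)cc1`, keeps the core of compound 1 and carries 2,4-dichlorophenyl in place of 4-acetamidophenyl on a sulfonyl sulfur, (2,4-dichlorophenyl in place of 4-acetamidophenyl on a sulfonyl sulfur). No step beyond the scatter is expected in this assay. This expectation rests on compound 2, which also lacks the 4-acetamidophenyl group and gives 32400 nM. The estimated step, a 1.3-fold lower number from compound 1 to compound 3 (0.12 log units; within the scatter), is small and leans slightly towards a lower number. For compound 3 the estimated value is 18000 nM, with an expected range from 6000 nM to 50000 nM.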

Compound 3, concentration for 50% growth inhibition: 20900 nM
Compound 3: middle estimate off by 1.2-fold (0.06 log units), on the low side; low and high end bracket the measured number.
By their numbers in this assay, from the lowest: compounds 3, 1 and 2 (each within the scatter of the next).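

In this assay, among these compounds, the pair of compound 1 and compound 3 gives the series its only reading of a single change, and the step is a 1.1-fold lower number from compound 1 to compound 3 (0.06 log units; within the scatter). On this sulfonyl sulfur, then, 2,4-dichlorophenyl and 4-acetamidophenyl stand level, even though the hydrogen-bond donor, the hydrogen-bond acceptor and the double bond outside aromatic rings counted for 4-acetamidophenyl are all absent from 2,4-dichlorophenyl, which brings chlorine instead. Nothing measured alongside these numbers accounts for this level reading, which holds for this one pair only.

From the compounds shown here alone, it remains open whether any group on the sulfonyl sulfur would move the number beyond the scatter, for instance a carboxylic acid, an aliphatic amine or a plain alkyl chain in place of the aromatic ring. The compounds shown also give no single-change reading anywhere else on the shared core, so a group such as methoxy or morpholine elsewhere on that core remains an open case.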